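This account rests on a few compounds, and the source may have more. Where it says the series, first, only, none or still open, it means among the compounds named here.

Measured in a functional assay on KB cells (Homo sapiens) for cytotoxicity; on this read-out lower numbers stand for an effect already at smaller amounts and higher numbers for an effect only at larger amounts of compound:
- compound 1 `COC1=C(C)C(=O)/C(=C(O)/C=C/c2cccc(OC)c2)C(=O)C1(C)C`: 3.3 ug/mL
- compound 2 `COC1=C(C)C(=O)/C(=C(O)/C=C/c2ccc(F)cc2)C(=O)C1(C)C`: 3.7 ug/mL
- compound 3 `COC1=C(C)C(=O)/C(=C(O)/C=C/c2ccccc2C)C(=O)C1(C)C`: 4.1 ug/mL

On these numbers, compound 3 cannot be told apart from the other two: a 1.2-fold higher number from compound 1 to compound 3 (0.09 log units; within the scatter) and a 1.1-fold higher number from compound 2 to compound 3 (0.04 log units; within the scatter) both lie within the scatter. Compound 4 `COC1=C(C)C(=O)/C(=C(O)/C=C/c2ccco2)C(=O)C1(C)C` differs from it at one place: furan-2-yl in place of 2-methylphenyl on a double-bonded chain carbon bound to a double-bonded chain carbon. Here, furan-2-yl takes the place of 2-methylphenyl on a double-bonded chain carbon bound to a double-bonded chain carbon. The same place was varied in the measured compounds, and a 1.1-fold higher number from compound 1 to compound 2 (0.05 log units; within the scatter) also stayed within the scatter. None of them carries a five-membered aromatic ring, however, so this evidence is indirect. In this assay, no step beyond the scatter is therefore expected. The estimated step is a 1.2-fold lower number from compound 3 to compound 4 (0.07 log units; within the scatter). For compound 4 the expected value is 3.5 ug/mL, with an estimated range from 1.5 ug/mL to 8 ug/mL.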

Compound 4, concentration for half-maximal effect: 9.9 ug/mL
For compound 4 the middle estimate is 2.8-fold (0.45 log units) below the measured one; the whole stated range lies below it.
By their numbers in this assay, from the lowest: compounds 1, 2 and 3 (each within the scatter of the next); then compound 4.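

In this assay furan-2-yl on a double-bonded chain carbon bound to a double-bonded chain carbon gave a 2.4-fold higher number from compound 3 to compound 4 (0.38 log units; beyond the scatter) and also a 2.7-fold higher number from compound 2 to compound 4 (0.43 log units; beyond the scatter) and a 3.0-fold higher number from compound 1 to compound 4 (0.48 log units; beyond the scatter). This position therefore does respond to the group it carries, although the three substituted phenyl groups had stayed within the scatter of one another. No evidence is available that explains this difference.

From the compounds shown here alone, it remains open whether the ring size or the ring oxygen goes with the higher number. A thiophen-2-yl or a pyridinyl group could separate these two.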